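Triazole isomer swap on the diphenylmethyl core

A few compounds are considered here, and "the series" means these few. Any claim that something is new, unique, unknown or untested is made for them only; others in the source may bear on it.

Compound 1 `c1ccc(C(c2ccccc2)n2ccnn2)cc1` is the reference point of the series. Among the compounds with values here, in an assay on isolated protein for inhibition of Aromatase (Homo sapiens), read by fluorescence and colorimetric assay, with a stated time of 30 min (on this read-out lower numbers stand for stronger inhibition and higher numbers for weaker inhibition), compound 1 gives 4580 nM, the lowest of the three numbers so far. Compound 2 `c1ccc(OCc2cn(C(c3ccccc3)c3ccccc3)nn2)cc1` gives 31300 nM and compound 3 `Clc1ccc(OCc2cn(C(c3ccccc3)c3ccccc3)nn2)cc1` gives 13400 nM in this assay. The steps of a 6.8-fold higher number from compound 1 to compound 2 (0.83 log units; beyond the scatter) and a 2.9-fold higher number from compound 1 to compound 3 (0.47 log units; beyond the scatter) show that adding phenoxymethyl or (4-chlorophenoxy)methyl to the aromatic carbon of the core weakens inhibition, while a 2.3-fold lower number from compound 2 to compound 3 (0.37 log units; beyond the scatter) shows the chloro variant recovering part of that loss.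

Compound 4 `c1ccc(C(c2ccccc2)n2cncn2)cc1` differs from compound 1 only in the ring itself: 1H-1,2,4-triazol-1-yl in place of 1H-1,2,3-triazol-1-yl on a saturated chain carbon bound to two aromatic carbons. Within the data shown here, none of the measured steps touches this change; all three concern substitution on the ring, not its nitrogen arrangement. The step is therefore judged from the unsubstituted reference alone, and a modest move in either direction would not be surprising.

For compound 4 the step expected is a 2.3-fold lower number from compound 1 to compound 4 (0.36 log units; beyond the scatter), leaning toward a lower number, with a wide range. The estimate for compound 4 in this assay is 2000 nM, between 400 nM and 10000 nM.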

Compound 4, half-maximal inhibitory concentration: 1100 nM
Compound 4: middle estimate off by 1.8-fold (0.26 log units), on the high side, within the range that was stated.
By their numbers in this assay, from the lowest: compound 4; then compound 1; then compound 3; then compound 2.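

In this assay, the arrangement of the ring nitrogens alone moves the number: with 1H-1,2,4-triazol-1-yl in place of 1H-1,2,3-triazol-1-yl on a saturated chain carbon bound to two aromatic carbons, the result is a 4.2-fold lower number from compound 1 to compound 4 (0.62 log units; beyond the scatter). The earlier steps shown here all concern substitution on the ring and could not show this; here the atoms and the counts of donors and acceptors stay the same, and the number still changes beyond the scatter. No measurement at hand accounts for the difference between these two rings.

As far as these compounds go, it remains open whether phenoxymethyl or (4-chlorophenoxy)methyl would shift the number on the 1H-1,2,4-triazol-1-yl ring as they do on the ring of compound 2 and compound 3. Also open, from the compounds shown here alone, is how an imidazole or a tetrazole would compare at the same place.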